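The source may hold more compounds than are shown below. What is called first, only, known or untested is meant among the compounds shown, and "the series" means these compounds.

Compound 1 `Cn1nc(-c2cccnc2)c2ccccc2c1=O` in an assay on isolated protein (Oryctolagus cuniculus) with Thromboxane-A synthase (Homo sapiens) as the target, tested at 1 uM (on this read-out lower numbers stand for less inhibition and higher numbers for more inhibition at the one concentration tested (going by the name of the read-out)), gives 63%. Compound 2 `CC(=O)Cn1nc(-c2cccnc2)c2ccccc2c1=O` gives 13% in this assay, the lowest of the two numbers. Among the compounds with values here, the one measured step is a number 50 percentage points lower from compound 1 to compound 2 (beyond the scatter). Compound 3 `O=C(c1cccs1)n1nc(-c2cccnc2)c2ccccc2c1=O` carries (thiophen-2-yl)carbonyl in place of 2-oxopropyl on an aromatic nitrogen. Within the data shown here, no measured step covers this change; the known step replaced hydrogen with acetyl and was large downward, whereas compound 3 keeps a carbonyl on the aromatic nitrogen within a larger group, so the step is read as uncertain. The expected step is a number 12 percentage points higher from compound 2 to compound 3 (beyond the scatter), not clearly beyond the scatter. Compound 3 is estimated at 25%, range 5% to 55%.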

Compound 3, a percentage reported as inhibition, at one concentration (the size of the read-out at that concentration, not a potency): 37%
Compound 3: middle estimate off by 12 percentage points, on the low side, and the stated range covers the measured number.
By their numbers in this assay, from the lowest: compound 2; then compound 3; then compound 1.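

At the aromatic nitrogen in this assay, replacing 2-oxopropyl with (thiophen-2-yl)carbonyl gives a number 24 percentage points higher from compound 2 to compound 3 (beyond the scatter), so the number does not fall steadily as the group gains heavy atoms. Set against methyl, the same group gives a number 26 percentage points lower from compound 1 to compound 3 (beyond the scatter), leaving compound 1 highest of the three. Nothing available explains these differences. Whether the carbonyl or the five-membered aromatic ring accounts for the rise over compound 2 remains open. So does whether an amine, a carboxylic acid or a longer chain on this nitrogen would match compound 1.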